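From a 3-methylphenyl to a 4-ethylphenyl group

The source may report more compounds than this note shows. Statements on the series, on what has been measured and on what is new or still open speak of the compounds shown alone.

compound 1 `O=C1OC[C@H](Cc2ccccc2F)[C@H]1Cc1ccc(Cl)c(Cl)c1` gives 28000 nM
compound 2 `O=C1OC[C@H](Cc2cccc(O)c2)[C@H]1Cc1ccc(Cl)c(Cl)c1` gives 48000 nM
compound 3 `Cc1cccc(C[C@H]2COC(=O)[C@@H]2Cc2ccc(Cl)c(Cl)c2)c1` gives 22000 nM

These values come from a functional assay on HL-60 cells (Homo sapiens) for cytotoxicity, read by WST assay, with a stated time of 48 h (a lower number here means that less compound is needed, a higher number that more compound is needed for the effect), and all three compounds share one core. Compound 3 stands level with compound 1 on these numbers, with a 1.3-fold lower number from compound 1 to compound 3 (0.10 log units; within the scatter) as the gap between them. It parts from compound 2 by a 2.2-fold lower number from compound 2 to compound 3 (0.34 log units; beyond the scatter) as the only gap that clears the scatter.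

The next step leads to compound 4 `CCc1ccc(C[C@H]2COC(=O)[C@@H]2Cc2ccc(Cl)c(Cl)c2)cc1` and brings 4-ethylphenyl in place of 3-methylphenyl on a saturated chain carbon bound to a saturated ring carbon with 4-ethylphenyl in place of 3-methylphenyl on a saturated chain carbon bound to a saturated ring carbon.

Among the compounds with values here, three measured steps bear on this change, since each alters the same aromatic group. Besides the two already given, a 1.7-fold higher number from compound 1 to compound 2 (0.23 log units; within the scatter) completes the set. All three are small, and the largest is only modest. Within the data shown here, no measured compound carries an ethyl group, so the data do not test that group directly. With compound 3 at 22000 nM as the starting point, no step beyond the scatter is expected in this assay and neither direction is favoured. The expected step is a 1.1-fold higher number from compound 3 to compound 4 (0.06 log units; within the scatter) on this estimate. For compound 4 the estimated value is 25000 nM with an expected range from 10000 nM to 60000 nM in repeated measurements.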

Compound 4, half-maximal effective concentration: 16000 nM
Compound 4: the middle estimate sits 1.6-fold (0.19 log units) above what was measured; the measured number falls inside the stated range.
By their numbers in this assay, from the lowest: compounds 4, 3, 1 and 2 (each within the scatter of the next, the first and the last beyond it).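

In this assay, within the data shown here, the place on a saturated chain carbon bound to a saturated ring carbon accepts 4-ethylphenyl, a group of 8 carbons, with no step that clears the scatter against either 3-methylphenyl (a 1.4-fold lower number from compound 3 to compound 4 (0.14 log units; within the scatter)) or 2-fluorophenyl (a 1.8-fold lower number from compound 1 to compound 4 (0.24 log units; within the scatter)). Only the comparison with the 3-hydroxyphenyl group of compound 2 goes beyond the scatter, and it remains modest (a 3.0-fold lower number from compound 2 to compound 4 (0.48 log units; beyond the scatter)), so the first ethyl-bearing ring in this set leaves compound 4 level with compounds 3 and 1 and apart from compound 2 alone. Nothing available here accounts for these steps.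

The compounds shown leave open whether a longer chain such as 4-butylphenyl, or a ring carrying an amine or a carboxylic acid, would shift the number further at this place. They also leave open how far the number depends on the dichlorophenyl group, which is the same in all four compounds.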